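The compounds below may be only part of what the source reports. "The series", "measured", "known", "first", "only" and "open" are said of these compounds alone.

Compound 3 `CNC(=O)c1cc(C(=O)Nc2cnn(C)c2)cc2c1OC[C@H]2c1ccccc1` gives 3.5 in a physicochemical assay for lipophilicity, at pH 7.4 (a lower number here means a more polar compound, a higher number a more lipophilic compound), the highest of the three numbers available; compound 1 `CNC(=O)c1cc(C(=O)N[C@H]2[C@@H]3COC[C@@H]32)cc2c1OC[C@H]2c1ccccc1` gives 3.3, within the scatter of compound 3, while compound 2 `CNC(=O)c1cc(C(=O)N[C@H]2[C@@H]3COC[C@@H]32)cc2c1OC[C@H]2c1cccnc1` gives 1.4, far lower. Compound 4 `CNC(=O)c1cc(C(=O)NC)c2c(c1)[C@H](c1ccccc1)CO2` has not yet been measured in this assay. Its difference from compound 3 is methyl in place of 1-methyl-1H-pyrazol-4-yl on an amide-type nitrogen. Among the compounds with values here, only one measured step touches the amide-type nitrogen: a number 0.20 log units higher from compound 1 to compound 3 (within the scatter), which swapped one six-atom group for another at that position and changed little. The large step of a number 1.90 log units lower from compound 1 to compound 2 (beyond the scatter) concerns a different position and does not bear here. Within the data shown here, no measured step removes a ring at the amide nitrogen altogether, so the expectation rests on the loss of five heavy atoms, including an aromatic ring, and a modest drop is expected: compound 4 is estimated at 2.8, within 2.2 to 3.4, an expected step of a number 0.70 log units lower from compound 3 to compound 4 (beyond the scatter).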

Compound 4, distribution coefficient: 3.2
Estimate against measurement, compound 4: 0.40 log units below; measured number inside the range.
By their numbers in this assay, from the lowest: compound 2; then compounds 4, 1 and 3 (each within the scatter of the next).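

In this assay, methyl in place of 1-methyl-1H-pyrazol-4-yl on the amide-type nitrogen gives a number 0.30 log units lower from compound 3 to compound 4 (within the scatter), and one carbon atom in place of the larger group carried by compound 1 gives a number 0.10 log units lower from compound 1 to compound 4 (within the scatter). Earlier, this position had only been compared between two groups of equal heavy-atom count; now a single methyl, with no ring, also stays within the scatter of both, so compound 1, compound 3 and compound 4 are not separated by this read-out. No measurement at hand accounts for this.

Going by these compounds, whether a carboxylic acid, an amine or a longer alkyl chain on this nitrogen would stay within the same scatter remains open. So does whether methyl behaves alike with the pyridin-3-yl group of compound 2, the only compound here that carries it.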